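The source may hold more compounds than are shown below. What is called first, only, known or untested is meant among the compounds shown, and "the series" means these compounds.

Measured compounds:
compound 1, `COc1ccc2nc(C)cc(OCC(=O)Nc3cccc(C)c3)c2c1`: 39800 nM
compound 2, `COc1ccc(NC(=O)COc2cc(C)nc3ccc(OC)cc23)cc1`: > 100000 nM
compound 3, `COc1ccc2nc(C)cc(OCC(=O)Nc3cc(C)ccc3OC)c2c1`: > 100000 nM

In a toxicity assay on HepG2 cells (Homo sapiens) for inhibition, read by CellTiter-Glo, with a stated time of 48 h (a higher number here means a weaker inhibitor, a lower number a stronger inhibitor), compound 1 gives 39800 nM. For compound 2 the assay reports only a limit, > 100000 nM. For compound 3 it likewise reports only a limit, > 100000 nM. Compound 3 therefore sits at the limit of > 100000 nM in this assay, at which 2 of the 3 values shown sit, at the weak end of what the numbers show, and no number places it in order against compound 2.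

The change from compound 3 to compound 4 is 3,5-difluorophenyl in place of 2-methoxy-5-methylphenyl on an amide-type nitrogen, giving compound 4 as `COc1ccc2nc(C)cc(OCC(=O)Nc3cc(F)cc(F)c3)c2c1`. Among the measured compounds shown here, two measured steps bear on it. The step of an at least 2.5-fold higher number from compound 1 to compound 3 (0.40 log units; beyond the scatter) shows that adding methoxy to the ring on the amide-type nitrogen carried the number from a measured value to the limit; the step of an at least 2.5-fold higher number from compound 1 to compound 2 (0.40 log units; beyond the scatter) did the same with a different ring. The step that the two limits leave unreadable from compound 2 to compound 3 is not readable, as both of its values are limits. Compound 4 carries no methoxy on that ring, as compound 1 does not, and its ring otherwise resembles the 3-methylphenyl of compound 1 in bearing only small groups. The expectation is therefore a modest fall from the limit, a step of an at least 1.6-fold lower number from compound 3 to compound 4 (0.22 log units; that floor lies within the scatter), though a value staying at the limit remains quite possible. Compound 4 is estimated at 60000 nM, within 20000 nM to 150000 nM.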

Compound 4, half-maximal inhibitory concentration: > 100000 nM
Compound 4: a limit, no number (the forecaster's own chance of this, stated with the estimate: 45%); at least 1.6-fold (0.22 log units) between middle value and limit.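

In this assay compound 4 gives only a limit, > 100000 nM. The step of an at least 2.5-fold higher number from compound 1 to compound 4 (0.40 log units; beyond the scatter) shows that the ring on the amide-type nitrogen can carry the number to the limit without any methoxy on it, which compound 2 and compound 3, both bearing methoxy on that ring, could not show. The steps among compound 2, compound 3 and compound 4 cannot be read, as each joins two limits, so compound 1 remains the only compound with a measured number at this position: the limit of > 100000 nM in this assay, at which 3 of the 4 values shown sit.

The compounds shown leave open whether the single methyl of the 3-methylphenyl ring is what keeps compound 1 measurable, or whether a 3-ethylphenyl, 3-chlorophenyl or 3-fluorophenyl ring on the same nitrogen would also give a number rather than a limit. They also leave open whether an amine or a carboxylic acid on that ring, or a longer chain between the amide and the core, would bring a value down from the limit, and how far apart compound 2, compound 3 and compound 4 truly lie.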